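Swapping the aryl group on a scaffold that shows no activity

The source may report more compounds than this note shows. Statements on the series, on what has been measured and on what is new or still open speak of the compounds shown alone.

Compound 3 `Nc1ncnn2c([C@@H]3O[C@H](CO)[C@@H](O)[C@H]3O)cc(-c3ccccc3F)c12` is one of three close relatives that share a sugar linked to a fused two-ring core. In a functional assay on K562 cells (Homo sapiens) for antiproliferative activity, with a stated time of 72 h (on this read-out lower numbers stand for stronger inhibition and higher numbers for weaker inhibition), compound 3 gives only a limit, > 100000 nM. Compound 1 `Nc1ncnn2c([C@@H]3O[C@H](CO)[C@@H](O)[C@H]3O)cc(C#Cc3cccs3)c12` likewise reaches only a limit in this assay, > 100000 nM. Compound 2 `Nc1ncnn2c([C@@H]3O[C@H](CO)[C@@H](O)[C@H]3O)cc(C#Cc3ccccc3)c12` also gives a limit in this assay, > 100000 nM. Because all three sit at the limit of > 100000 nM in this assay, at which 3 of the 3 values shown sit, the steps between them cannot be read in size: a step that the two limits leave unreadable from compound 1 to compound 2, a step that the two limits leave unreadable from compound 1 to compound 3 and a step that the two limits leave unreadable from compound 2 to compound 3. Compound 3 therefore stands level with both relatives, all of them at the limit.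

Compound 4 `Nc1ncnn2c([C@@H]3O[C@H](CO)[C@@H](O)[C@H]3O)cc(-c3ccsc3)c12` differs from compound 3 in one place: thiophen-3-yl in place of 2-fluorophenyl on an aromatic carbon. The two measured steps that end at compound 3 also exchange a group at this same aromatic carbon, and neither moved the value out of the limit, so there is no sign that a further change here brings the read-out into the measurable range. The step is expected to be a step that the limit leaves unreadable from compound 3 to compound 4, none beyond the scatter as far as it can be judged. Compound 4 is therefore estimated at 150000 nM, with a range from 30000 nM to 1000000 nM, most probably reported once more as a limit.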

Compound 4, half-maximal inhibitory concentration: 66400 nM
Estimate against measurement, compound 4: 2.3-fold (0.35 log units) above; measured number inside the range.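

In this assay compound 4 is the only one of the four to give a measured number, 66400 nM, so a group on this aromatic carbon can bring the read-out into the measurable range. Replacing 2-fluorophenyl with thiophen-3-yl gives an at least 1.5-fold lower number from compound 3 to compound 4 (0.17 log units; that floor lies within the scatter), replacing 2-phenylethynyl gives an at least 1.5-fold lower number from compound 2 to compound 4 (0.17 log units; that floor lies within the scatter), and replacing 2-(thiophen-2-yl)ethynyl gives an at least 1.5-fold lower number from compound 1 to compound 4 (0.17 log units; that floor lies within the scatter). Each of these steps is only a floor, so the true change could be larger or could stay within the scatter, since the starting compound in each pair has no number of its own: the limit of > 100000 nM in this assay, at which 3 of the 4 values shown sit.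

The compounds shown leave open how large the real gain from thiophen-3-yl is, and whether the sulfur-containing ring matters more than the direct attachment to the core, as directly attached thiophen-2-yl or furan-3-yl could test. They also leave open whether an amine or a carboxylic acid on this same aromatic carbon would give a number well below that of compound 4.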